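The compounds below may be only part of what the source reports. "The series", "measured", "known", "first", "only" and "open" are said of these compounds alone.

Compound 2 `CCC1(O)CCN(c2nc(C)c3cc(NC(=O)COc4ccc(OC(F)(F)F)cc4)ccc3n2)CC1` stands at 59 nM in a functional assay on CHO-K1 cells for antagonist activity at melanin-concentrating hormone receptor 1 (Homo sapiens), read by inositol phosphate accumulation (a lower number here means a stronger inhibitor, a higher number a weaker inhibitor), the lowest of the three numbers in hand. Compound 1 `Cc1nc(N2CCN(C3CCOCC3)CC2)nc2ccc(NC(=O)COc3ccc(Cl)cc3)cc12` gives 115 nM in this assay, a gap to compound 2 that lies within the scatter, so no order between the two can be read. Compound 3 `Cc1nc(N2CCN(C)CC2)nc2ccc(NC(=O)COc3ccc(Cl)cc3)cc12` gives 3800 nM, far beyond the scatter from compound 2. For the measured compounds named here, the only one-place step measured here is a 33-fold higher number from compound 1 to compound 3 (1.52 log units; beyond the scatter), which concerns the group on the amine nitrogen of the ring and not the carbon that carries the hydroxyl.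

Compound 4 `Cc1nc(N2CCC(O)(C3CC3)CC2)nc2ccc(NC(=O)COc3ccc(OC(F)(F)F)cc3)cc12` differs from compound 2 by cyclopropyl in place of ethyl on a saturated ring carbon. Going by the values given here, no measured pair changes this carbon, so nothing in hand speaks for a shift in either direction, and the expectation is that the step of a 1.0-fold higher number from compound 2 to compound 4 (0.01 log units; within the scatter) stays within the scatter. Compound 4 is therefore estimated at 60 nM in this assay, with a range from 25 nM to 150 nM.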

Compound 4, half-maximal inhibitory concentration: 33 nM
Beside the measured number, compound 4's estimate is 1.8-fold (0.26 log units) above it, and the stated range covers the measured number.
By their numbers in this assay, from the lowest: compounds 4, 2 and 1 (each within the scatter of the next, the first and the last beyond it); then compound 3.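

In this assay, for the compounds shown here, the first pair that changes this saturated ring carbon gives a 1.8-fold lower number from compound 2 to compound 4 (0.25 log units; within the scatter), so cyclopropyl in place of ethyl brings no readable change. The 4-hydroxypiperidin-1-yl group therefore carries the three-membered ring of carbon as well as it carries the open two-carbon chain, with no loss beyond the scatter. Nothing at hand offers an explanation for how the two groups compare.

From the compounds shown here alone, the hydroxyl on this carbon stays the same in compound 2 and compound 4, so what a methoxy or an amine would do in its place remains open. Going by these compounds, it also remains open whether a longer chain, such as butyl, or a larger ring, such as cyclohexyl, on this carbon would stay within the scatter of these two compounds.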